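Chloro to nitro on a phenyl ring: a cell test

The compounds below may be only part of what the source reports. "The series", "measured", "known", "first", "only" and "open" are said of these compounds alone.

Measured in an ADME assay on L6 cells (Rattus norvegicus) for cytotoxicity, read by resazurin assay, with a stated time of 72 h; a higher number here means a weaker inhibitor, a lower number a stronger inhibitor:
Compound 1 `O=C1[C@H]2N=NN(Cc3nc(-c4ccccc4)no3)[C@H]2C(=O)N1c1ccccc1`: 47.3 ug/mL
Compound 2 `O=C1[C@H]2N=NN(Cc3nc(-c4ccc(Cl)cc4)no3)[C@H]2C(=O)N1c1ccccc1`: 49.5 ug/mL

Compound 2 stands level with compound 1, since their two values lie within the scatter of repeated measurements. The next compound to be tested is compound 3 `O=C1[C@H]2N=NN(Cc3nc(-c4ccc([N+](=O)[O-])cc4)no3)[C@H]2C(=O)N1c1ccccc1`. It differs from compound 2 by nitro in place of chloro on an aromatic carbon. In other words, a 4-nitrophenyl group takes the place of the 4-chlorophenyl group.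

Within the data shown here, only one measured step bears on this change. Putting chloro in place of hydrogen on an aromatic carbon gave a 1.0-fold higher number from compound 1 to compound 2 (0.02 log units; within the scatter), which is within the scatter. Among the measured compounds shown here, that single step shows that one swap on this ring left the number in this assay unmoved, but no nitro compound has been measured yet, so the evidence is thin. No change beyond the scatter is expected, and the estimated step is a 1.1-fold lower number from compound 2 to compound 3 (0.04 log units; within the scatter). For compound 3 the expected value is 45 ug/mL, with an estimated range of 22 ug/mL to 90 ug/mL.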

Compound 3, half-maximal inhibitory concentration: > 100 ug/mL
Compound 3 gave a limit, no number; the forecaster's own chance of this, stated with the estimate: 8%; middle value at least 2.2-fold (0.34 log units) from the limit.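

Nitro in place of hydrogen gives an at least 2.1-fold higher number from compound 1 to compound 3 (0.32 log units; beyond the scatter), so in this assay this aromatic carbon, para to a large group, is not indifferent to what it carries, something the chloro step alone could not show. Nitro in place of chloro gives an at least 2.0-fold higher number from compound 2 to compound 3 (0.30 log units; that floor lies within the scatter), and that floor by itself does not separate the two compounds, so the real gap between them could be small or large. Compound 3 carries a limit and not a number, which makes both steps to it floors rather than measured sizes: the limit of > 100 ug/mL in this assay, at which 1 of the 3 values shown sits.

From the compounds shown here alone, how far the true value of compound 3 lies past that limit remains open, and so does the full size of the change from chloro to nitro. Also open is whether this shift belongs to nitro alone or would also appear with another group on the same carbon, such as an amine or a carboxylic acid, since the compounds shown hold only hydrogen, chloro and nitro there.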